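Series notes: from compound 3 to compound 4

A few compounds are considered here, and "the series" means these few. Any claim that something is new, unique, unknown or untested is made for them only; others in the source may bear on it.

In a functional assay on MCF7 cells (Homo sapiens) (a lower number here means a stronger inhibitor of growth, a higher number a weaker inhibitor of growth), compound 3 (`O=S(=O)(/C=C/c1ccc(C(F)(F)F)cc1F)Cc1ccc(Nc2ncnc3ccc(Br)cc23)cc1`) gives 32000 nM and sits level with compound 1 (`O=S(=O)(/C=C/c1ccc(O)cc1)Cc1ccc(Nc2ncnc3ccc(Br)cc23)cc1`) at 32000 nM, the high end of the three numbers. Compound 2 (`O=S(=O)(/C=C/c1ccc(Cl)cc1Cl)Cc1ccc(Nc2ncnc3ccc(Br)cc23)cc1`) gives 4000 nM in the same read-out.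

Compound 4 (`O=S(=O)(/C=C/c1ccc(C(F)(F)F)cc1F)Cc1ccc(Nc2ncnc3cc(Cl)ccc23)cc1`) carries this change: a group of 11 heavy atoms (8 carbon, 2 nitrogen, 1 chlorine; one six-membered aromatic ring of carbon only, one six-membered aromatic ring with 2 hetero atoms) in place of a group of 11 heavy atoms (8 carbon, 2 nitrogen, 1 bromine; one six-membered aromatic ring of carbon only, one six-membered aromatic ring with 2 hetero atoms), on a nitrogen on an aromatic ring. The entering group is 7-chloroquinazolin-4-yl.

The measured steps, an 8.0-fold lower number from compound 1 to compound 2 (0.90 log units; beyond the scatter) and an 8.0-fold higher number from compound 2 to compound 3 (0.90 log units; beyond the scatter) and also no change at the digits printed from compound 1 to compound 3 (within the scatter), all alter the aryl group on the double-bonded chain carbon. None alters the group on the nitrogen, so they bear on this change only weakly. The expected step is a 1.1-fold lower number from compound 3 to compound 4 (0.03 log units; within the scatter) in this assay, with none beyond the scatter anticipated. For compound 4 the estimate is 30000 nM with an expected range of 10000 nM to 90000 nM in this read-out.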

Compound 4, concentration for 50% growth inhibition: > 100000 nM
Compound 4 was reported as a limit; the forecaster's own chance of this, stated with the estimate: 20%; middle value at least 3.3-fold (0.52 log units) from the limit.
By their numbers in this assay, from the lowest: compound 2; then compounds 1 and 3 (each within the scatter of the next). At a limit, above all of these: compound 4.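

Going by these compounds alone, only this step alters the group on the nitrogen on an aromatic ring, and in this assay 7-chloroquinazolin-4-yl in place of the bromine-bearing group gives an at least 3.1-fold higher number from compound 3 to compound 4 (0.49 log units; beyond the scatter). Growth inhibition in this series therefore responds to this group as well as to the aryl group varied across compounds 1 to 3. For compound 4 the reading is a limit, not a number: the limit of > 100000 nM in this assay, at which 1 of the 4 values shown sits.

The compounds shown do not separate the exchange of bromine for chlorine from the shift in where the halogen sits. As far as these compounds go, it also remains open how a 7-bromo, 7-methoxy or 7-amino group would read here, or how 7-chloroquinazolin-4-yl would read with the 2,4-dichlorophenyl group.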